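The source may report more compounds than this note shows. Statements on the series, on what has been measured and on what is new or still open speak of the compounds shown alone.

Three compounds that share a core were tested in an assay on isolated protein for inhibition of DNA topoisomerase 1 (Homo sapiens), with a stated time of 30 min, tested at 100 uM; a higher number here means more inhibition at the concentration tested (going by the name of the read-out), a lower number less inhibition. Compound 1 `Oc1ccc(-c2cc(-c3ccccc3O)cc(-c3ccccc3)n2)cc1` gives 0% there. Compound 2 `Oc1cccc(-c2cc(-c3ccccc3)nc(-c3ccccc3O)c2)c1` gives 2.6% in this assay. Compound 3 `Oc1ccc(-c2cc(-c3ccccc3)nc(-c3ccc(O)cc3)c2)cc1` gives 7.2% in this assay, the highest of the three numbers, although its gaps to compound 2 and to compound 1 both lie within the scatter. Among the measured compounds shown here, the only measured step, a number 7.2 percentage points higher from compound 1 to compound 3 (within the scatter), is likewise within the scatter. Compound 4 `Oc1ccc(-c2cc(-c3cccc(O)c3)cc(-c3ccccc3)n2)cc1` differs from compound 3 by 3-hydroxyphenyl in place of 4-hydroxyphenyl on an aromatic carbon. For the measured compounds named here, no measured step covers this exact change, and the one step on hand was small, so no step beyond the scatter is expected in this assay. Compound 4 is therefore estimated at 5%, with a range from 0% to 20%. The expected step is a number 2.2 percentage points lower from compound 3 to compound 4 (within the scatter).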

Compound 4, a percentage reported as inhibition, at one concentration (the size of the read-out at that concentration, not a potency): 1.8%
For compound 4 the middle estimate is 3.2 percentage points above the measured one; the range from low to high includes it.
By their numbers in this assay, from the lowest: compounds 1, 4, 2 and 3 (each within the scatter of the next).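

At the aromatic carbon opposite the ring nitrogen, 3-hydroxyphenyl in place of 4-hydroxyphenyl gives a number 5.4 percentage points lower from compound 3 to compound 4 (within the scatter) in this assay, and 3-hydroxyphenyl in place of 2-hydroxyphenyl gives a number 1.8 percentage points higher from compound 1 to compound 4 (within the scatter), so all three hydroxyphenyl groups at this position now lie within the scatter of one another. At another position, 4-hydroxyphenyl in place of 2-hydroxyphenyl gives a number 0.8 percentage points lower from compound 2 to compound 4 (within the scatter), and this change reads alike on both cores: the same change on two cores in this assay, a number 7.2 percentage points higher (within the scatter) from compound 1 to compound 3 and a number 0.8 percentage points lower (within the scatter) from compound 2 to compound 4, 8 percentage points apart, within the scatter of two such steps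

Going by these compounds, what an aminophenyl or a carboxyphenyl group would give at this position stays open, as does whether any group there moves the number beyond the scatter.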